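Exchanging one ring on the shared core

The source may hold more compounds than are shown below. What is called first, only, known or untested is meant among the compounds shown, and "the series" means these compounds.

In a functional assay on DU-145 cells (Homo sapiens) for inhibition, read by trypan blue exclusion, with a stated time of 96 h (on this read-out lower numbers stand for stronger inhibition of growth and higher numbers for weaker inhibition of growth), compound 1 `O=C(/C(=C\c1ccc(Br)cc1)S(=O)(=O)c1ccc(Br)cc1)c1ccc(Br)cc1` gives 10000 nM, compound 2 `O=C(/C(=C\c1ccc(I)cc1)S(=O)(=O)c1ccc(Br)cc1)c1ccc(Br)cc1` gives 1000 nM and compound 3 `O=C(/C(=C\c1ccc(F)cc1Cl)S(=O)(=O)c1ccc(Br)cc1)c1ccc(Br)cc1` gives 50000 nM, the highest number of the three and so the weakest growth inhibition. Compound 4 `Nc1c(Br)cc(Br)cc1/C=C(\C(=O)c1ccc(Br)cc1)S(=O)(=O)c1ccc(Br)cc1` is still unmeasured. It differs from compound 3 by 2-amino-3,5-dibromophenyl in place of 2-chloro-4-fluorophenyl on a double-bonded chain carbon bound to a double-bonded chain carbon, with 2-amino-3,5-dibromophenyl in place of 2-chloro-4-fluorophenyl. Among the measured compounds shown here, two measured steps bear on this place: a 5.0-fold higher number from compound 1 to compound 3 (0.70 log units; beyond the scatter) and a 50-fold higher number from compound 2 to compound 3 (1.70 log units; beyond the scatter). For the measured compounds named here, both rings with a single large halogen gave lower numbers, yet no measured compound carries an amino group, so the expectation stays loose. In this assay, the expected change is an 8.3-fold lower number from compound 3 to compound 4 (0.92 log units; beyond the scatter). For compound 4 the estimated value is 6000 nM, within an expected range of 1000 nM to 40000 nM.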

Compound 4, concentration for 50% growth inhibition: 25000 nM
For compound 4 the middle estimate is 4.2-fold (0.62 log units) below the measured one; the measured number falls inside the stated range.
By their numbers in this assay, from the lowest: compound 2; then compound 1; then compounds 4 and 3 (each within the scatter of the next).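

In this assay the 2-amino-3,5-dibromophenyl ring does not separate from the 2-chloro-4-fluorophenyl ring, with a 2.0-fold lower number from compound 3 to compound 4 (0.30 log units; within the scatter). The same ring gives weaker growth inhibition than either ring with one halogen, with a 2.5-fold higher number from compound 1 to compound 4 (0.40 log units; beyond the scatter) and a 25-fold higher number from compound 2 to compound 4 (1.40 log units; beyond the scatter), so among these four compounds the lower numbers belong only to 4-bromophenyl and 4-iodophenyl. Nothing measured here explains these differences. The compounds shown leave open whether the amino group or the two bromines set the number of compound 4, and how a ring bearing a methoxy group or a carboxylic acid would compare at this place.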